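Methyl on an Aromatic Nitrogen: Expectation for Compound 3

The source may report more compounds than this note shows. Statements on the series, on what has been measured and on what is new or still open speak of the compounds shown alone.

The two measured compounds were read in a functional assay on MT4 cells (Homo sapiens) for antiproliferative activity, read by MTT assay, with a stated time of 96 h; on this read-out lower numbers stand for an effect already at smaller amounts and higher numbers for an effect only at larger amounts of compound. Compound 1 `Cn1cc(/C=C(\C#N)S(C)(=O)=O)c2ccccc21` gives in this assay only a limit, > 100000 nM. Compound 2 `N#C/C(=C\c1c[nH]c2ccccc12)S(=O)(=O)c1ccccc1` likewise gives in this assay only a limit, > 100000 nM. Both values shown therefore sit at the limit of > 100000 nM in this assay, at which 2 of the 2 values shown sit, so compound 2 stands at the edge of what this assay reports, side by side with compound 1, and no order between the two can be drawn from these numbers.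

Compound 3 `Cn1cc(/C=C(\C#N)S(=O)(=O)c2ccccc2)c2ccccc21` differs from compound 2 by methyl in place of hydrogen on an aromatic nitrogen. For the measured compounds named here, no measured pair shows this change on its own; compound 1 carries the same methyl but a different sulfonyl group, so it offers no clean comparison. With both neighbours at the limit, the step that the limit leaves unreadable from compound 2 to compound 3 is expected to amount to nothing beyond the usual scatter in this assay. Compound 3 is accordingly expected near 150000 nM, within 50000 nM to 500000 nM, and most probably returned again only as a limit.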

Compound 3, half-maximal effective concentration: > 100000 nM
Compound 3 gave a limit, no number; the forecaster's own chance of this, stated with the estimate: 85%; the middle value lies beyond the limit too.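

In this assay compound 3 gives > 100000 nM as a limit and not a number. For the compounds shown here, no step from compound 1 or compound 2 to compound 3 can be read: the limit of > 100000 nM in this assay, at which 3 of the 3 values shown sit. The compounds shown leave open whether methyl on the aromatic nitrogen or phenyl on the sulfonyl sulfur alters this read-out at all.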